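This account rests on a few compounds, and the source may have more. Where it says the series, first, only, none or still open, it means among the compounds named here.

Measured in an ADME assay on MT4 cells (Homo sapiens) for cytotoxicity, read by MTT assay, with a stated time of 3 days; a higher number here means that more compound is tolerated, a lower number that less compound is tolerated:
- compound 1 `CC(=O)Oc1ccc(CN(C(=O)COC(=O)c2ccc([N+](=O)[O-])o2)C(C)(C)C)cc1`: > 100000 nM (a limit)
- compound 2 `COc1ccc(CN(C(=O)COC(=O)c2ccc([N+](=O)[O-])o2)C(C)(C)C)cc1`: > 100000 nM (a limit)

Compound 2 stands at > 100000 nM, which is a limit and not a number. Compound 3 `CC(C)(C)N(Cc1ccc(OCc2ccccc2)cc1)C(=O)COC(=O)c1ccc([N+](=O)[O-])o1` differs from it by phenyl in place of hydrogen on a saturated chain carbon bound to an oxygen on an aromatic ring, that is, methoxy to benzyloxy. Among the compounds with values here, the only measured step bearing on this is a step that the two limits leave unreadable from compound 1 to compound 2, also a change on the oxygen on the aromatic ring, and it has no readable size. The evidence is thin: the limit of > 100000 nM in this assay, at which 2 of the 2 values shown sit. In this assay the expected result is an at least 1.6-fold lower number from compound 2 to compound 3 (0.22 log units; that floor lies within the scatter), in the direction of less compound tolerated, and another limit is quite possible. For compound 3 the estimated value is 60000 nM, with an expected range of 15000 nM to 100000 nM.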

Compound 3, half-maximal cytotoxic concentration: "not active" (no number reported)
Compound 3: no number reported, so the estimate cannot be set against anything.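

Within the data shown here, compound 3 is reported only as "not active", without a number, so no step from compound 2 to compound 3 can be read. The compounds shown leave open whether any change on the oxygen on the aromatic ring, methoxy to benzyloxy included, shifts the half-maximal cytotoxic concentration at all.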